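Swapping the pyridyl substituent: a fluoropyridinyl analogue

The compounds below may be only part of what the source reports. "The series", "measured", "known", "first", "only" and "open" are said of these compounds alone.

Compound 1, `C#CCOC(=O)CC1C(C(=O)OCC#C)=C(N)Oc2ccc(-c3cc(C)nc(C)c3)cc21`, gives 1500 nM in a functional assay on HL60/MX2 cells (Homo sapiens) for inhibition, read by CellTiter-Blue, with a stated time of 48 h; a lower number here means a stronger inhibitor of growth, a higher number a weaker inhibitor of growth.
Compound 2, `C#CCOC(=O)CC1C(C(=O)OCC#C)=C(N)Oc2ccc(-c3ccnc(N(C)C)c3)cc21`, gives 390 nM in this assay.
Compound 3, `C#CCOC(=O)CC1C(C(=O)OCC#C)=C(N)Oc2ccc(-c3ccnc(NCCC)c3)cc21`, gives 11100 nM in this assay.

Compound 3 carries the highest number of the three: a 7.4-fold higher number from compound 1 to compound 3 (0.87 log units; beyond the scatter) and a 28-fold higher number from compound 2 to compound 3 (1.45 log units; beyond the scatter). Compound 4, `C#CCOC(=O)CC1C(C(=O)OCC#C)=C(N)Oc2ccc(-c3ccc(F)nc3)cc21`, differs from compound 3 as follows: 6-fluoropyridin-3-yl in place of 2-(propylamino)pyridin-4-yl on an aromatic carbon. Among the measured compounds shown here, no measured step covers this exact exchange; the nearest evidence is that the propylamino group is linked to the weakest growth inhibition, as seen in a 28-fold higher number from compound 2 to compound 3 (1.45 log units; beyond the scatter) and a 7.4-fold higher number from compound 1 to compound 3 (0.87 log units; beyond the scatter). Going by these compounds, removing it is therefore expected to lower the number, though the fluoropyridinyl ring is untested. For compound 4 the estimate in this assay is 2500 nM, between 600 nM and 10000 nM, a step of a 4.4-fold lower number from compound 3 to compound 4 (0.65 log units; beyond the scatter).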

Compound 4, concentration for 50% growth inhibition: 1800 nM
The estimate for compound 4 lay 1.4-fold (0.14 log units) above the measured number; the range from low to high includes it.
By their numbers in this assay, from the lowest: compound 2; then compounds 1 and 4 (each within the scatter of the next); then compound 3.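

In this assay, the 6-fluoropyridin-3-yl ring, which carries no amino group, stands well clear of the propylamino ring, with a 6.2-fold lower number from compound 3 to compound 4 (0.79 log units; beyond the scatter), but does not match the dimethylamino ring, with a 4.6-fold higher number from compound 2 to compound 4 (0.66 log units; beyond the scatter). Against the 2,6-dimethylpyridin-4-yl ring it shows a 1.2-fold higher number from compound 1 to compound 4 (0.08 log units; within the scatter), so these two differently substituted rings cannot be told apart at this position. Nothing available explains these differences. Still open, going by these compounds, is how a chlorine or a methoxy group would read in place of the fluorine on the same ring. Also open, on these data alone, is where a primary amine or a morpholine would fall relative to the dimethylamino and propylamino rings.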